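A few compounds are considered here, and "the series" means these few. Any claim that something is new, unique, unknown or untested is made for them only; others in the source may bear on it.

Measured in a physicochemical assay for solubility, in phosphate buffer, with a stated time of 24 h, at pH 7.4, tested at 100 uM; a higher number here means a more soluble compound, a lower number a less soluble compound:

- compound 1 `CCC(=O)N1CCC(S(=O)(=O)c2ccc(CNC(=O)N3Cc4ccncc4C3)cc2)CC1` gives 216000 nM
- compound 2 `O=C(NCc1ccc(S(=O)(=O)C2CCN(C3COC3)CC2)cc1)N1Cc2ccncc2C1` gives 121000 nM
- compound 3 `CN1CCC(S(=O)(=O)c2ccc(CNC(=O)N3Cc4ccncc4C3)cc2)CC1` gives 240000 nM

Compound 3 is not separated from either of the other two. Its steps, a 1.1-fold higher number from compound 1 to compound 3 (0.05 log units; within the scatter) and a 2.0-fold higher number from compound 2 to compound 3 (0.30 log units; within the scatter), both lie within the scatter, so the three compounds form a single group on these numbers.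

The next compound is compound 4 `CN1CCN(S(=O)(=O)c2ccc(CNC(=O)N3Cc4ccncc4C3)cc2)CC1`, which differs from compound 3 by 4-methylpiperazin-1-yl in place of 1-methylpiperidin-4-yl on a sulfonyl sulfur. In words, this is 4-methylpiperazin-1-yl in place of 1-methylpiperidin-4-yl on a sulfonyl sulfur.

Among the compounds with values here, no measured step makes this change. The three available steps, a 1.8-fold lower number from compound 1 to compound 2 (0.25 log units; within the scatter) together with the two above, all exchange a group on an amine nitrogen in a ring, so they bear on it only indirectly. They show that this assay stayed within the scatter across those exchanges, and on that evidence no step beyond the scatter is expected here. A slight drop from compound 3 is allowed for, as its value of 240000 nM is the top of a small group.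

The expected change is a 1.4-fold lower number from compound 3 to compound 4 (0.15 log units; within the scatter).

For compound 4 the estimated value is 170000 nM, with an expected range from 90000 nM to 280000 nM.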

Compound 4, solubility: 160000 nM
Beside the measured number, compound 4's estimate is 1.1-fold (0.03 log units) above it, within the range that was stated.
By their numbers in this assay, from the lowest: compounds 2, 4, 1 and 3 (each within the scatter of the next).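

In this assay the exchange now falls on the sulfonyl sulfur itself, whereas every earlier step touched only a group on an amine nitrogen in a ring, and 4-methylpiperazin-1-yl, with its ring of 2 hetero atoms, in place of 1-methylpiperidin-4-yl, with its ring of 1 hetero atom, gives a 1.5-fold lower number from compound 3 to compound 4 (0.18 log units; within the scatter). The two other exchanges at this sulfur, which also replace the larger 1-(oxetan-3-yl)piperidin-4-yl and 1-propanoylpiperidin-4-yl, give a 1.3-fold higher number from compound 2 to compound 4 (0.12 log units; within the scatter) and a 1.4-fold lower number from compound 1 to compound 4 (0.13 log units; within the scatter), so the four compounds remain a single group on these numbers, and a change at this place has now been read as well as one on the ring nitrogen. Nothing available here accounts for this result.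

The compounds shown leave open whether any group on the sulfonyl sulfur moves the number beyond the scatter, since all four carry a six-membered ring with at least one nitrogen there. From the compounds shown here alone, an open-chain amine or a morpholin-4-yl group at that place, or a carboxylic acid on the ring, could test this, and any change to the shared core remains unexplored in these data.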